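Ethyl in place of fluoro on compound 2

The source may hold more compounds than are shown below. What is called first, only, known or untested is meant among the compounds shown, and "the series" means these compounds.

Compound 1 `CCC(/C=C1\OC(=O)NC1=O)(CC)c1ccc(-c2ccc3cc(F)cc(F)c3c2)[nH]c1=O` gives 45 nM in a functional assay on CHO cells for antagonist activity at prostaglandin E2 receptor EP3 subtype (Homo sapiens), read by cAMP accumulation, with a stated time of 30 min (a higher number here means a weaker inhibitor, a lower number a stronger inhibitor), and compound 2 `CCC(/C=C1\OC(=O)NC1=O)(CC)c1ccc(-c2ccc3cccc(F)c3c2)[nH]c1=O` gives 61 nM in this assay. On the two numbers measured, compound 2 stands at the top with compound 1 nearest, but the gap is within the scatter and does not separate them. Among the compounds with values here, the one measured step, a 1.4-fold higher number from compound 1 to compound 2 (0.13 log units; within the scatter), is hydrogen in place of fluoro on an aromatic carbon and stays within the scatter. Compound 3 `CCc1cccc2ccc(-c3ccc(C(/C=C4\OC(=O)NC4=O)(CC)CC)c(=O)[nH]3)cc12` differs from compound 2 by ethyl in place of fluoro on an aromatic carbon. Within the data shown here, no measured step brings an ethyl onto the core, so a 1.4-fold higher number from compound 1 to compound 2 (0.13 log units; within the scatter) bears on it only indirectly, showing that removing the fluoro left the number where it was. For compound 3 the step of a 1.1-fold higher number from compound 2 to compound 3 (0.06 log units; within the scatter) is expected to stay within the scatter, with no clear direction. Compound 3 is estimated at 70 nM in this assay, with a range of 25 nM to 200 nM.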

Compound 3, half-maximal inhibitory concentration: 91 nM
For compound 3 the middle estimate is 1.3-fold (0.11 log units) below the measured one; low and high end bracket the measured number.
By their numbers in this assay, from the lowest: compounds 1, 2 and 3 (each within the scatter of the next, the first and the last beyond it).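

Within the data shown here, the earlier step concerned the other fluoro of compound 1, so this is the first reading at the fluoro kept in compound 2, on the aromatic carbon ortho to a fused ring. In this assay, ethyl in place of that fluoro gives a 1.5-fold higher number from compound 2 to compound 3 (0.17 log units; within the scatter), so at this position two carbon atoms can replace one fluorine without a step beyond the scatter. This single pair does not give a direction for the change, and no supporting measurement offers an explanation for the reading.

Going by these compounds, how this position responds to hydrogen, a longer chain such as butyl, an amine or a carboxylic acid stays open. Also open, on these data alone, is whether ethyl reads the same when the second fluoro of compound 1 is present.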